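Compound 3: a second 4-(pyridin-2-yl)phenyl group

This account rests on a few compounds, and the source may have more. Where it says the series, first, only, none or still open, it means among the compounds named here.

In a functional assay on HCT-116 cells (Homo sapiens) for cytotoxicity, read by fluorescence, with a stated time of 72 h (on this read-out higher numbers stand for weaker inhibition and lower numbers for stronger inhibition), compound 1 (`CC(C)c1n[nH]c2c(NCc3ccc(-c4ccccn4)cc3)nc(S(C)(=O)=O)nc12`) gives 1140 nM and compound 2 (`CC(C)c1n[nH]c2c(NCc3ccc(-c4ccccn4)cc3)nc(NCC(C)(C)O)nc12`) gives 85 nM as the lower of the two numbers. For the measured compounds named here, the one measured step (a 13-fold lower number from compound 1 to compound 2 (1.13 log units; beyond the scatter)) is large and beyond the scatter, and it bears only indirectly, as a different change on the same side of the core. Compound 3 (`CC(C)c1n[nH]c2c(NCc3ccc(-c4ccccn4)cc3)nc(NCc3ccc(-c4ccccn4)cc3)nc12`) carries 4-(pyridin-2-yl)phenyl in place of 1-hydroxy-1-methylethyl on a saturated chain carbon bound to a nitrogen on an aromatic ring. Going by the values given here, no measured step covers this group, so only a moderate rise is expected (a 2.9-fold higher number from compound 2 to compound 3 (0.47 log units; beyond the scatter)). Compound 3 is estimated at 250 nM (expected range 60 nM to 1500 nM).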

Compound 3, half-maximal inhibitory concentration: 7330 nM
Compound 3: the middle estimate sits 29-fold (1.47 log units) below what was measured; measured number above the stated range.
By their numbers in this assay, from the lowest: compound 2; then compound 1; then compound 3.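

In this assay, putting 4-(pyridin-2-yl)phenyl in place of 1-hydroxy-1-methylethyl gives an 86-fold higher number from compound 2 to compound 3 (1.94 log units; beyond the scatter) and places compound 3 highest of the three. For the compounds shown here, the earlier compounds showed only that swapping the group on the aromatic carbon could lower the number; this step shows that the number also depends strongly on what sits on the saturated chain carbon. Nothing available accounts for this rise.

On these data alone, whether the rise follows the loss of the hydroxyl or the arrival of the two rings remains open. So does how a plain phenyl, a primary amine or a carboxylic acid would read at this place.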